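Turning the double bond of compound 2 from E to Z

The compounds below may be only part of what the source reports. "The series", "measured", "known", "first", "only" and "open" are said of these compounds alone.

compound 1 `COc1cc(/C=C\c2ccc3ccccc3c2)cc(N)c1OC`: 1640 nM
compound 2 `COc1c(N)cc(/C=C/c2ccc3ccccc3c2)cc1N`: > 5000 nM

In a functional assay on HeLa cells (Homo sapiens) for inhibition (a higher number here means a weaker inhibitor, a lower number a stronger inhibitor), compound 2 gives > 5000 nM as a limit of the assay and not a number. This places compound 2 on the limit of > 5000 nM in this assay, at which 1 of the 2 values shown sits, among the data so far. Compound 3 `COc1c(N)cc(/C=C\c2ccc3ccccc3c2)cc1N` brings one change: the two compounds have the same atoms and bonds and differ only in configuration as drawn: 1 of 1 stereo elements differ; a double bond is drawn E in compound 2 and Z in compound 3 and nothing else. Compound 1, whose double bond is also drawn Z, gives a true number of 1640 nM in this assay and so suggests that a stronger result is expected. The expected change is an at least 6.2-fold lower number from compound 2 to compound 3 (0.79 log units; beyond the scatter) toward a lower number. For compound 3 the estimated value is 800 nM with 100 nM to 5000 nM as the expected range.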

Compound 3, half-maximal inhibitory concentration: > 5000 nM
Compound 3: no number, only a limit; the forecaster's own chance of this, stated with the estimate: 15%; at least 6.2-fold (0.79 log units) between middle value and limit.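

In this assay compound 3 gives > 5000 nM, a limit of the assay and not a number. Turning the double bond from E to Z therefore yields no readable step, as both compounds sit on a limit: the limit of > 5000 nM in this assay, at which 2 of the 3 values shown sit. With the double bond drawn Z in both compounds, amino in place of methoxy on an aromatic carbon gives an at least 3.0-fold higher number from compound 1 to compound 3 (0.48 log units; beyond the scatter), so this swap, not the Z double bond alone, separates a true number from a limit.

Among these compounds, the effect of the double bond's configuration remains open, since no pair with an E and a Z form has two true numbers. From the compounds shown here alone, it is also open how a hydroxyl group would fare at the place where compound 1 carries methoxy and compound 3 carries amino.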